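Swapping a Dichlorophenoxy Arm for a Fluorobenzylamine

A few compounds are considered here, and "the series" means these few. Any claim that something is new, unique, unknown or untested is made for them only; others in the source may bear on it.

Compound 1 `Nc1cc(N)c2nc(-c3ccccc3)c(Oc3ccc(Cl)c(Cl)c3)nc2c1` is tested in a functional assay on UACC-257 cells (Homo sapiens) for inhibition, read by sulforhodamine B assay, with a stated time of 48 h; a lower number here means that less compound is tolerated, a higher number that more compound is tolerated. In this assay compound 1 gives < 100000 nM, which is a limit of the assay rather than a measured number. Two related compounds are also recorded. Compound 2 `CCOC(=O)[C@H](CCC(=O)O)NC(=O)c1ccc(Sc2nc3cc(N)cc(N)c3nc2-c2ccccc2)cc1` gives 95500 nM in this assay. Compound 3 `CCOC(=O)[C@H](CCC(=O)O)NC(=O)c1ccc(Oc2nc3cc(N)cc(N)c3nc2-c2ccccc2)cc1` gives < 100000 nM in this assay, again a limit rather than a number. Compound 1 therefore stands where most of these readings sit, as the limit of < 100000 nM in this assay, at which 2 of the 3 values shown sit, shows. Compound 4 `Nc1cc(N)c2nc(-c3ccccc3)c(NCc3ccc(F)cc3)nc2c1` differs from compound 1 by (4-fluorobenzyl)amino in place of 3,4-dichlorophenoxy on an aromatic carbon. Among the compounds with values here, no measured pair shows this change, so its size cannot be read from the data. The step that the limit leaves unreadable from compound 1 to compound 4 in this assay is expected to be small, within the usual scatter. Compound 4 is estimated at 60000 nM, between 15000 nM and 100000 nM.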

Compound 4, concentration lethal to 50% of the cells: 8910 nM
Beside the measured number, compound 4's estimate is 6.7-fold (0.83 log units) above it, and the stated range ends above it.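

No size can be read for the step between compound 1 and compound 4, since compound 1 is recorded only as a limit: the limit of < 100000 nM in this assay, at which 2 of the 4 values shown sit.

The compounds shown leave open how far (4-fluorobenzyl)amino in place of 3,4-dichlorophenoxy shifts the reading.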